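The source may report more compounds than this note shows. Statements on the series, on what has been measured and on what is new or still open speak of the compounds shown alone.

Measured compounds:
- Compound 1, `O=C(Oc1ccc(-c2cncn2C2CCN(C(=O)c3ccc(Cl)c(C(F)(F)F)c3)CC2)cc1)c1ccccc1`, in an assay on HEK293 cells for antagonist activity at P2X purinoceptor 7 (Homo sapiens), read by fluorescence, with a stated time of 2 h (a lower number here means a stronger inhibitor, a higher number a weaker inhibitor), gives > 10000 nM, which is a limit of the assay and not a number.
- Compound 2, `O=C(c1ccc(Cl)c(C(F)(F)F)c1)N1CCC(n2cncc2-c2ccc(OS(=O)(=O)c3cccc(Br)c3)cc2)CC1`, in this assay gives 896 nM.

Going by the values given here, compound 2 thus holds the only actual number measured in this assay; the other value shown is a limit. Among the compounds with values here, the single measured step, an at least 11-fold lower number from compound 1 to compound 2 (1.04 log units; beyond the scatter), concerns the group on an oxygen on an aromatic ring, and it carries the series from the limit of > 10000 nM in this assay, at which 1 of the 2 values shown sits, to a measurable number. Compound 3, `CCN(CC)C(=O)c1cccc(S(=O)(=O)Oc2ccc(-c3cncn3C3CCN(C(=O)c4ccc(Cl)c(C(F)(F)F)c4)CC3)cc2)c1`, keeps the sulfonyl link of compound 2 and changes only one substituent: diethylcarbamoyl in place of bromo on an aromatic carbon. No measured step touches this place, so the step from compound 2 to compound 3 has no direct precedent, and the one step shown gives no guide to its direction. The expectation is therefore a change within the scatter, with a wide range reflecting the absence of any comparable step. Compound 3 is expected to give about 1200 nM in this assay, within 300 nM to 6000 nM, which corresponds to an estimated step of a 1.3-fold higher number from compound 2 to compound 3 (0.13 log units; within the scatter).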

Compound 3, half-maximal inhibitory concentration: 202 nM
Compound 3: the middle estimate sits 5.9-fold (0.77 log units) above what was measured; measured number below the stated range.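

Going by these compounds alone, the substituent on this aromatic carbon, a place that no earlier step touched, is not neutral in this assay: diethylcarbamoyl in place of bromo gives a 4.4-fold lower number from compound 2 to compound 3 (0.65 log units; beyond the scatter). The place therefore accepts a far larger substituent, with 7 heavy atoms and a hydrogen-bond acceptor entering where a single bromine atom leaves, and the number still falls beyond the scatter. Nothing measured here shows which feature of the entering group accounts for this step.

The compounds shown leave open whether the carbonyl or the two ethyl chains carry the gain, and a shorter dimethylcarbamoyl, a simple carbamoyl with its amide hydrogens, a carboxylic acid or an amine at the same carbon would begin to separate these parts. Within the data shown here, they also leave open whether diethylcarbamoyl would give a similar number on another carbon of this ring, and whether a step at this place would hold with the sulfonyl link replaced, since the single change from benzoyl was read against a limit of the assay.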